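Swapping bromo for methoxy on a shared core

The compounds below may be only part of what the source reports. "The series", "measured", "known", "first", "only" and "open" are said of these compounds alone.

Measured so far in a functional assay on the whole organism (plasma, strain Wistar) with Rattus norvegicus as the target, with a stated time of 15 days, at a dose of 10 mg/kg by the oral route; on this read-out higher numbers stand for a stronger effect at the one dose given and lower numbers for a weaker effect:
compound 1 `O=C1NC(=O)/C(=C/c2ccc(OCCSc3nnc(-c4ccc([N+](=O)[O-])cc4)[nH]3)cc2)S1` gives 13.9%
compound 2 `O=C1NC(=O)/C(=C/c2ccc(OCCSc3nnc(-c4ccccc4[N+](=O)[O-])[nH]3)cc2)S1` gives 15.3%
compound 3 `O=C1NC(=O)/C(=C/c2ccc(OCCSc3nnc(-c4ccc(Br)cc4)[nH]3)cc2)S1` gives 20.4%

Compound 3 has the highest of the three numbers in this assay, but its lead over compound 2, a number 5.1 percentage points higher from compound 2 to compound 3 (within the scatter), and over compound 1, a number 6.5 percentage points higher from compound 1 to compound 3 (within the scatter), both lie within the scatter, so the three compounds cannot be ranked against each other. The remaining step, a number 1.4 percentage points higher from compound 1 to compound 2 (within the scatter), is also within the scatter.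

Compound 4 `COc1ccc(-c2nnc(SCCOc3ccc(/C=C4\SC(=O)NC4=O)cc3)[nH]2)cc1` differs from compound 3 in one place: methoxy in place of bromo on an aromatic carbon. Going by the values given here, none of the measured steps exchanges bromo for methoxy, so no step bears directly on this change; the closest comparison is that moving between nitro and bromo, or between two nitro positions, left the read-out within the scatter. On that basis the step of a number 3.4 percentage points lower from compound 3 to compound 4 (within the scatter) is expected to stay small, with no clear direction. Compound 4 is therefore estimated at 17%, within a range from 8% to 28%.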

Compound 4, a percentage reported as activity, at one dose (the size of the read-out at that dose, not a potency): 33.6%
Estimate against measurement, compound 4: 16.6 percentage points below; the whole stated range lies below it.
By their numbers in this assay, from the lowest: compounds 1, 2 and 3 (each within the scatter of the next); then compound 4.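

Methoxy in place of bromo gives the first step at this aromatic carbon that clearly exceeds the scatter in this assay (a number 13.2 percentage points higher from compound 3 to compound 4 (beyond the scatter)), whereas the earlier changes between bromo and nitro groups did not. Compound 4 also stands clear of both nitro compounds (a number 18.3 percentage points higher from compound 2 to compound 4 (beyond the scatter)) and (a number 19.7 percentage points higher from compound 1 to compound 4 (beyond the scatter)), so this one change separates it from the three compounds that could not be ranked against one another. Nothing available here accounts for this difference between methoxy and the other groups.

The compounds shown leave open whether a dimethylamino group, a hydroxyl group or a longer ethoxy chain on the same carbon would match compound 4. They also do not show whether methoxy would give a similar result at another carbon of that ring.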